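The source may report more compounds than this note shows. Statements on the series, on what has been measured and on what is new or still open speak of the compounds shown alone.

Compound 1 `O=C1COc2ccc(-c3cccc(NS(=O)(=O)c4ccc(F)cc4)c3)cc2N1C1CC1`, compound 2 `O=C1COc2ccc(-c3cccc(NS(=O)(=O)c4ccc(F)cc4)c3)cc2N1c1ccccc1` and compound 3 `Cc1ccc(N2C(=O)COc3ccc(-c4cccc(NS(=O)(=O)c5ccc(F)cc5)c4)cc32)cc1` share one core and differ only in the group on the amide-type nitrogen in the ring. In a functional assay on HeLa cells (Homo sapiens) for antiproliferative activity, read by MTT assay, with a stated time of 72 h (a lower number here means a stronger inhibitor, a higher number a weaker inhibitor), compound 1 gives only a limit, > 40000 nM. In this assay compound 2 gives 17700 nM. In this assay compound 3 again gives only a limit, > 40000 nM. Compound 3 thus stands at the limit of > 40000 nM in this assay, at which 2 of the 3 values shown sit; the step of an at least 2.2-fold higher number from compound 2 to compound 3 (0.35 log units; beyond the scatter) can be read only against that limit, and a step that the two limits leave unreadable from compound 1 to compound 3. Compound 4 `COc1cccc(N2C(=O)COc3ccc(-c4cccc(NS(=O)(=O)c5ccc(F)cc5)c4)cc32)c1` carries 3-methoxyphenyl in place of 4-methylphenyl on an amide-type nitrogen in a ring. For the measured compounds named here, no measured step alters the aryl group in this way; the only aryl change, an at least 2.2-fold higher number from compound 2 to compound 3 (0.35 log units; beyond the scatter), moved the number to the limit. Compound 4 is therefore expected to show an at least 1.1-fold lower number from compound 3 to compound 4 (0.05 log units; that floor lies within the scatter). Compound 4 is estimated at 35000 nM, between 15000 nM and 80000 nM.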

Compound 4, half-maximal inhibitory concentration: > 40000 nM
Compound 4: no number, only a limit; the forecaster's own chance of this, stated with the estimate: 55%; middle value at least 1.1-fold (0.05 log units) away from the limit.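

Putting a methoxy group on the plain phenyl group gives an at least 2.2-fold higher number from compound 2 to compound 4 (0.35 log units; beyond the scatter), so a second substituted phenyl group, and not only 4-methylphenyl, loses the measurable value seen with the plain phenyl group. The steps to compound 4 from compound 1 and from compound 3 cannot be read, as both ends are limits. Compound 4 gives only a limit in this assay, and only compound 2 among the four gives a number: the limit of > 40000 nM in this assay, at which 3 of the 4 values shown sit.

Going by these compounds, the rank of 3-methoxyphenyl against 4-methylphenyl stays open. So does whether an amine or a carboxylic acid on the phenyl group would give a number at all.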